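Trifluoromethyl for cyano: expected shift in cell tolerance

The source may hold more compounds than are shown below. What is called first, only, known or untested is meant among the compounds shown, and "the series" means these compounds.

Compound 1 `CN(C)CCCCOC(=O)Nc1ccc(Cn2nc(-c3ccccc3)c3ccccc3c2=O)cc1`: 16000 nM
Compound 2 `CN(C)CCCCOC(=O)Nc1ccc(Cn2nc(-c3ccc(C(F)(F)F)cc3)c3ccccc3c2=O)cc1`: 3360 nM
Compound 3 `CN(C)CCCCOC(=O)Nc1ccc(Cn2nc(-c3cccc(C#N)c3)c3ccccc3c2=O)cc1`: 17200 nM

In an ADME assay on Huh-7 cells (Homo sapiens) for cytotoxicity, read by MTT assay, with a stated time of 48 h (a higher number here means that more compound is tolerated, a lower number that less compound is tolerated), compound 3 gives the highest number of the three, though its gap to compound 1 lies within the scatter; only compound 2 stands apart, shown by a 5.1-fold higher number from compound 2 to compound 3 (0.71 log units; beyond the scatter). Compound 4 `CN(C)CCCCOC(=O)Nc1ccc(Cn2nc(-c3cccc(C(F)(F)F)c3)c3ccccc3c2=O)cc1` differs from compound 3 by trifluoromethyl in place of cyano on an aromatic carbon. Within the data shown here, two measured steps bear on this. Adding cyano left the number unchanged, as a 1.1-fold higher number from compound 1 to compound 3 (0.03 log units; within the scatter) shows, whereas adding trifluoromethyl lowered it, as a 4.8-fold lower number from compound 1 to compound 2 (0.68 log units; beyond the scatter) shows. A lower number in this assay is therefore expected for compound 4, though the group now sits on a different carbon, so the size is uncertain. Compound 4 is estimated at 5500 nM, within 2000 nM to 15000 nM, a step of a 3.1-fold lower number from compound 3 to compound 4 (0.50 log units; beyond the scatter).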

Compound 4, half-maximal cytotoxic concentration: 11600 nM
Compound 4: the middle estimate sits 2.1-fold (0.32 log units) below what was measured; measured number inside the range.
By their numbers in this assay, from the lowest: compound 2; then compounds 4, 1 and 3 (each within the scatter of the next).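

In this assay, trifluoromethyl on this aromatic carbon, meta to a large group, cannot be told apart from nitrile (a 1.5-fold lower number from compound 3 to compound 4 (0.17 log units; within the scatter)) or from hydrogen (a 1.4-fold lower number from compound 1 to compound 4 (0.14 log units; within the scatter)). The lower number seen earlier therefore belongs to compound 2 and does not follow trifluoromethyl wherever it sits, since shifting the group from the 4-(trifluoromethyl)phenyl to the 3-(trifluoromethyl)phenyl arrangement gives a 3.5-fold higher number from compound 2 to compound 4 (0.54 log units; beyond the scatter). Nothing available explains this dependence on place. On these data alone, how an amine or a carboxylic acid would behave on this carbon stays open, and so does whether a nitrile would respond to the same shift.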